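The source may report more compounds than this note shows. Statements on the series, on what has been measured and on what is new or still open speak of the compounds shown alone.

Measured so far:
compound 1, `Fc1ccc(-c2cc3ccccc3[nH]2)cc1`, 21.8%
compound 2, `Clc1ccccc1-c1cc2ccccc2[nH]1`, 21.5%
compound 3, `Nc1ccccc1C#Cc1cc(F)cc(F)c1`, 9.27%

In an assay on isolated protein for inhibition of Aromatase (Homo sapiens), read by fluorescence, using NADPH, with a stated time of 30 min, tested at 50 uM (on this read-out lower numbers stand for less inhibition and higher numbers for more inhibition at the one concentration tested (going by the name of the read-out)), compound 1 gives 21.8%. The number for compound 2 lies within the usual scatter of that of compound 1, so the two cannot be told apart, while compound 3 falls beyond the scatter below compound 1. Compound 4, `Nc1ccc(-c2cc3ccccc3[nH]2)cc1`, is the compound still to be measured; it differs from compound 1 in one place: amino in place of fluoro on an aromatic carbon. For the measured compounds named here, no step between two measured compounds is available to guide this change, so the account rests on compound 1 alone. In this assay a step of a number 1.8 percentage points lower from compound 1 to compound 4 (within the scatter) is expected, one that does not clearly exceed the scatter in either direction. For compound 4 the estimate is 20%, with a range from 5% to 38%.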

Compound 4, a percentage reported as inhibition, at one concentration (the size of the read-out at that concentration, not a potency): 46.2%
For compound 4 the middle estimate is 26.2 percentage points below the measured one; measured number outside the range, above it.
By their numbers in this assay, from the lowest: compound 3; then compounds 2 and 1 (each within the scatter of the next); then compound 4.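

In this assay, amino in place of fluoro on an aromatic carbon gives a number 24.4 percentage points higher from compound 1 to compound 4 (beyond the scatter), the first sign that this position responds to a single-group change. The earlier compounds shown here offered no such step, so they could not show this. Nothing measured here explains the step.

Going by these compounds, whether a hydroxyl or a dimethylamino group on the same carbon would keep this step remains open. Also open, on these data alone, is whether the amino group would give a similar step at another place on the same ring.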